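The source may hold more compounds than are shown below. What is called first, only, known or untested is meant among the compounds shown, and "the series" means these compounds.

Two compounds of this series have numbers in a functional assay on HepG2 cells (Homo sapiens) for cytotoxicity, read by MTT assay, with a stated time of 48 h; on this read-out higher numbers stand for weaker inhibition and lower numbers for stronger inhibition. Compound 1 `CN(C)CCNc1ccnc2cc(OCc3ccc(F)cc3)ccc12` gives 790 nM. Compound 2 `CCCCCCCCOc1ccc2c(Cl)ccnc2c1` gives 2640 nM, the higher of the two numbers; the gap to compound 1 lies beyond the scatter, so compound 2 is the weaker inhibitor of the pair. Among the compounds with values here, no step between measured compounds that differ in a single place is available.

Compound 3 `CCOc1ccc2c(Cl)ccnc2c1` is the next member to be measured in this assay. It differs from compound 2 by hydrogen in place of hexyl on a saturated chain carbon, two bonds along the chain from an oxygen on an aromatic ring, which shortens the octyl chain to ethyl. With no measured step of this kind in the series, the direction can only be guessed from compound 2 standing at 2640 nM. Compound 3 is expected to give 8000 nM, with a range of 2500 nM to 25000 nM. The expected step is a 3.0-fold higher number from compound 2 to compound 3 (0.48 log units; beyond the scatter), toward weaker inhibition, though a step within the scatter cannot be ruled out.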

Compound 3, half-maximal inhibitory concentration: 2660 nM
Beside the measured number, compound 3's estimate is 3.0-fold (0.48 log units) above it, within the range that was stated.
By their numbers in this assay, from the lowest: compound 1; then compounds 2 and 3 (each within the scatter of the next).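

Hydrogen in place of hexyl at this saturated chain carbon, two bonds along the chain from an oxygen on an aromatic ring, gives a 1.0-fold higher number from compound 2 to compound 3 (0.00 log units; within the scatter) in this assay. On this read-out, octyl and ethyl on that oxygen therefore cannot be told apart, so hexyl shows no measurable contribution in this pair. Within the data shown here, compound 1 differs from both in more than one place, which makes this the only single-place step so far, and nothing on hand accounts for its flatness.

From the compounds shown here alone, whether the flat reading extends to a longer chain such as decyl remains open. So does the outcome of an amine or a carboxylic acid at the end of the chain on this oxygen.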